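Swapping a sulfonyl for a fluorinated carbonyl on the aniline nitrogen

The source may hold more compounds than are shown below. What is called first, only, known or untested is meant among the compounds shown, and "the series" means these compounds.

Measured compounds:
compound 1 `CC(C)C/N=C(\S)N1CCN(c2ccc(N(Cc3c[nH]cn3)S(=O)(=O)c3ccccc3)cc2)CC1`, 800 nM
compound 2 `N#Cc1ccc(Cn2cncc2CN(c2ccc(N3CCN(C(=O)c4ccc(Cl)s4)CC3)cc2)S(=O)(=O)c2ccccc2)cc1`, 200 nM
compound 3 `N#Cc1ccc(Cn2cncc2CN(C(=O)c2ccccc2F)c2ccc(N3CCN(C(=O)c4ccc(Cl)s4)CC3)cc2)cc1`, 20 nM

In a functional assay on DLD-1 cells (Homo sapiens) (on this read-out lower numbers stand for stronger inhibition and higher numbers for weaker inhibition), compound 2 stands second highest of the three numbers; compound 1 lies a step above it beyond the scatter, and compound 3 a larger step below it. Compound 4 `N#Cc1ccc(Cn2cncc2CN(C(=O)c2cccc(F)c2)c2ccc(N3CCN(C(=O)c4ccc(Cl)s4)CC3)cc2)cc1` differs from compound 2 by (3-fluorophenyl)carbonyl in place of phenylsulfonyl on a nitrogen on an aromatic ring. Among the compounds with values here, one measured step bears on this: a 10-fold lower number from compound 2 to compound 3 (1.00 log units; beyond the scatter), where a (2-fluorophenyl)carbonyl entered at the same nitrogen. Since the entering group here is the same carbonyl with fluorine moved to the 3-position, a step of similar direction and size is expected, a 6.7-fold lower number from compound 2 to compound 4 (0.82 log units; beyond the scatter). Compound 4 is therefore expected to give about 30 nM, within 10 nM to 90 nM.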

Compound 4, half-maximal inhibitory concentration: 6 nM
Beside the measured number, compound 4's estimate is 5.0-fold (0.70 log units) above it; the measured number lies below the stated range.
By their numbers in this assay, from the lowest: compound 4; then compound 3; then compound 2; then compound 1.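

In this assay, a 33-fold lower number from compound 2 to compound 4 (1.52 log units; beyond the scatter) shows that replacing phenylsulfonyl with a fluorinated carbonyl group at this nitrogen can bring a larger gain than compound 3 alone indicated. The fluorine's location on the ring also matters, since a 3.3-fold lower number from compound 3 to compound 4 (0.52 log units; beyond the scatter) separates the (3-fluorophenyl)carbonyl group from its 2-fluorophenyl counterpart by more than the usual scatter. Nothing available explains this difference. Still open, from the compounds shown here alone, is whether fluorine is needed at all, and how a plain phenylcarbonyl group, or a chlorine or methoxy group in place of the fluorine, would compare.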